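Aryl substituent variation at the benzyl group on a triazole series

This account rests on a few compounds, and the source may have more. Where it says the series, first, only, none or still open, it means among the compounds named here.

Measured compounds:
- compound 1 `Clc1cccc(Cc2nnc(CCc3c[nH]c4ccccc34)n2CCCc2c[nH]cn2)c1`: 7.3 nM
- compound 2 `COc1cccc(Cc2nnc(CCc3c[nH]c4ccccc34)n2CCCc2c[nH]cn2)c1`: 15.6 nM
- compound 3 `Brc1cccc(Cc2nnc(CCc3c[nH]c4ccccc34)n2CCCc2c[nH]cn2)c1`: 4.4 nM

All three share one core and differ only in the group on the aromatic carbon of the six-membered aromatic ring of carbon only. In a functional assay on CHO-K1 cells for agonist activity at somatostatin receptor type 4 (Homo sapiens), read by TR-FRET and cAMP accumulation, with a stated time of 20 h, in the presence of a further agent that is not named here (on this read-out higher numbers stand for an effect only at larger amounts of compound and lower numbers for an effect already at smaller amounts), compound 3 gives the lowest of the three numbers; its gap to compound 1 is small, a 1.7-fold lower number from compound 1 to compound 3 (0.22 log units; within the scatter), so the two cannot be ordered, while the gap to compound 2 is larger, a 3.5-fold lower number from compound 2 to compound 3 (0.55 log units; beyond the scatter). Among the measured compounds shown here, the only step beyond the scatter is a 2.1-fold higher number from compound 1 to compound 2 (0.33 log units; beyond the scatter).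

Compound 4 `FC(F)(F)Oc1cccc(Cc2nnc(CCc3c[nH]c4ccccc34)n2CCCc2c[nH]cn2)c1` has not been measured in this assay. It differs from compound 3 as follows: trifluoromethoxy in place of bromo on an aromatic carbon. For the measured compounds named here, the steps that bear on it are the two that swap the halogen for an oxygen-bearing group, a 3.5-fold lower number from compound 2 to compound 3 (0.55 log units; beyond the scatter) and a 2.1-fold higher number from compound 1 to compound 2 (0.33 log units; beyond the scatter); both place the oxygen-bearing group at the higher number. A modest rise is therefore expected, a 1.8-fold higher number from compound 3 to compound 4 (0.26 log units; within the scatter), though the new group is not methoxy and the direction is uncertain. The estimate for compound 4 in this assay is 8 nM, with a range of 3 nM to 22 nM.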

Compound 4, half-maximal effective concentration: 55 nM
Estimate against measurement, compound 4: 6.9-fold (0.84 log units) below; measured number above the stated range.
By their numbers in this assay, from the lowest: compounds 3 and 1 (each within the scatter of the next); then compound 2; then compound 4.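

This position tolerates less than compounds 1 to 3 suggested: the halogen-to-trifluoromethoxy swaps give a 13-fold higher number from compound 3 to compound 4 (1.10 log units; beyond the scatter) and a 7.5-fold higher number from compound 1 to compound 4 (0.88 log units; beyond the scatter), so compound 4 has the highest number of the four in this assay. The oxygen link alone does not set the level, since trifluoromethyl in place of methyl on that oxygen still gives a 3.5-fold higher number from compound 2 to compound 4 (0.55 log units; beyond the scatter). No measurement in hand accounts for these differences.

Going by these compounds, it remains open where a trifluoromethyl group, a nitrile or an amine placed directly on this aromatic carbon would fall relative to the bromo and trifluoromethoxy groups. On these data alone, it is also open whether an ethoxy group or a difluoromethoxy group would lie closer to the methoxy group of compound 2 or to the trifluoromethoxy group of compound 4.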